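This account rests on a few compounds, and the source may have more. Where it says the series, first, only, none or still open, it means among the compounds named here.

Assay: a functional assay on HCT-116 cells (Homo sapiens) for inhibition, read by MTT assay, with a stated time of 72 h, in the presence of a further agent that is not named here; a higher number here means that more compound is needed for the effect, a lower number that less compound is needed

compound 1 (`O=C(Nc1cc(Cl)cc(Cl)c1)Nc1cc(Cl)nc(Cl)c1`) gives 11400 nM
compound 2 (`COc1cc(NC(=O)Nc2cc(Cl)nc(Cl)c2)cc(Cl)n1`) gives 11200 nM

Compound 2 at 11200 nM sits within the scatter of compound 1 at 11400 nM in this assay and the two cannot be told apart on these numbers.

Compound 3 (`O=C(Nc1cc(Cl)nc(Cl)c1)Nc1cc(Cl)nc(OC2CCCC2)c1`) keeps the rest of compound 2 and carries cyclopentyl in place of methyl on an oxygen on an aromatic ring, methoxy to cyclopentyloxy (cyclopentyl in place of methyl on an oxygen on an aromatic ring). Among the compounds with values here, no pair of measured compounds isolates this change, so the data give no direct guide to its size. Within the data shown here, with only two measured values, both within the scatter of each other, the working expectation is a small step, leaning toward a lower number and not clearly beyond the scatter. The estimated change is a 1.6-fold lower number from compound 2 to compound 3 (0.20 log units; within the scatter) and it remains a tentative expectation. For compound 3 the estimate is 7000 nM with an expected range of 2500 nM to 20000 nM in this assay and the measurement is still to come.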

Compound 3, half-maximal effective concentration: 5120 nM
Estimate against measurement, compound 3: 1.4-fold (0.14 log units) above; low and high end bracket the measured number.
By their numbers in this assay, from the lowest: compound 3; then compounds 2 and 1 (each within the scatter of the next).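

In this assay, the oxygen on an aromatic ring accepts cyclopentyl in place of methyl without loss, and the change gives a 2.2-fold lower number from compound 2 to compound 3 (0.34 log units; beyond the scatter), a modest step but one beyond the scatter. Within the data shown here, the earlier values gave no reading of this position, as compound 1 and compound 2 could not be told apart and no pair isolated a change at this oxygen; this pair now shows that the group there can alter the number, and that a carbon-only ring in place of a single carbon is compatible with activity in this assay. No measurement available here accounts for the size or direction of this step.

A single pair cannot separate the effect of the number of carbons from that of the ring itself, so the compounds shown leave open whether an open chain such as n-pentyl would match cyclopentyl, or whether isopropyl or cyclohexyl would give a smaller or larger step. As far as these compounds go, it also remains open how this oxygen substituent would fare with an amine or a carboxylic acid at the end of a longer chain.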